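Working notes on compound 4 and its measured neighbours

The compounds below may be only part of what the source reports. "The series", "measured", "known", "first", "only" and "open" are said of these compounds alone.

Compound 1 `Cc1ccc(Nc2nc(C(F)(F)F)ccc2CNC(=O)C(C)c2ccc(NS(C)(=O)=O)c(F)c2)cc1C` gives 39.3 nM in a functional assay on CHO-K1 cells for antagonist activity at transient receptor potential cation channel subfamily V member 1 (Homo sapiens), read by FLIPR (a higher number here means a weaker inhibitor, a lower number a stronger inhibitor), the second highest of the three numbers here. Compound 2 `CC(C(=O)NCc1ccc(C(F)(F)F)nc1NCc1ccc(Cl)cc1)c1ccc(NS(C)(=O)=O)c(F)c1` gives 65.7 nM; the step of a 1.7-fold higher number from compound 1 to compound 2 (0.22 log units; within the scatter) stays within the scatter. Compound 3 `CC(C(=O)NCc1ccc(C(F)(F)F)nc1N1CCC(c2ccccc2)CC1)c1ccc(NS(C)(=O)=O)c(F)c1` gives 0.6 nM, and a 66-fold lower number from compound 1 to compound 3 (1.82 log units; beyond the scatter) is the widest gap shown, with a 110-fold lower number from compound 2 to compound 3 (2.04 log units; beyond the scatter) similarly large. Compound 4 `CC(C(=O)NCc1ccc(C(F)(F)F)nc1N1CCC(O)CC1)c1ccc(NS(C)(=O)=O)c(F)c1` carries 4-hydroxypiperidin-1-yl in place of (3,4-dimethylphenyl)amino on an aromatic carbon. The two steps into compound 3 bear on this change, each yielding a far lower number once a 4-substituted piperidin-1-yl occupies that aromatic carbon; yet compound 4 lacks the phenyl of compound 3, so only part of that move is expected from compound 1: a 2.6-fold lower number from compound 1 to compound 4 (0.42 log units; beyond the scatter). Compound 4 is thus estimated at 15 nM, ranging from 3 nM to 80 nM.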

Compound 4, inhibition constant: "not active" (no number reported)
No number was reported for compound 4; the estimate stays without a comparison.
By their numbers in this assay, from the lowest: compound 3; then compounds 1 and 2 (each within the scatter of the next).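

Going by these compounds alone, compound 4 is reported as "not active" without a number in this assay, so no step linking it to compound 1, compound 2 or compound 3 can be read. The compounds shown leave open how much the phenyl of compound 3 contributes to its value. Nothing measured here bears on this result.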